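Cyano for methoxy on the aryl sulfonamide core

A few compounds are considered here, and "the series" means these few. Any claim that something is new, unique, unknown or untested is made for them only; others in the source may bear on it.

Compound 1 `COc1ccc(NS(=O)(=O)c2ccc(-c3ccccn3)s2)cc1N1C[C@@H](C)N[C@@H](C)C1` gives the lowest of the two numbers in a functional assay for agonist activity at growth hormone secretagogue receptor type 1 (Homo sapiens), read by FLIPR (on this read-out higher numbers stand for an effect only at larger amounts of compound and lower numbers for an effect already at smaller amounts), at 15.9 nM. For the measured compounds named here, its only measured neighbour, compound 2 `C[C@@H]1CN(c2cccc(NS(=O)(=O)c3ccc(-c4ccccn4)s3)c2)C[C@H](C)N1`, gives 39.8 nM in this assay, so the step of a 2.5-fold higher number from compound 1 to compound 2 (0.40 log units; beyond the scatter), hydrogen in place of methoxy, already goes beyond the scatter. Compound 3 `C[C@@H]1CN(c2cc(NS(=O)(=O)c3ccc(-c4ccccn4)s3)ccc2C#N)C[C@H](C)N1` differs from compound 1 by cyano in place of methoxy on an aromatic carbon. Going by the values given here, no measured step covers a cyano at this place; the single relevant step is the loss of the methoxy. For compound 3 a step in that same direction is expected, a 2.0-fold higher number from compound 1 to compound 3 (0.30 log units; within the scatter). Compound 3 is estimated at 32 nM, between 10 nM and 100 nM.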

Compound 3, half-maximal effective concentration: 631 nM
Compound 3: middle estimate off by 20-fold (1.29 log units), on the low side; the whole stated range lies below it.
By their numbers in this assay, from the lowest: compound 1; then compound 2; then compound 3.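

In this assay the change from methoxy to cyano gives a 40-fold higher number from compound 1 to compound 3 (1.60 log units; beyond the scatter) and so costs far more than losing the methoxy alone. Cyano also falls short of plain hydrogen, with a 16-fold higher number from compound 2 to compound 3 (1.20 log units; beyond the scatter) as the step, so on this aromatic carbon, ortho to a 3,5-dimethylpiperazin-1-yl group, the numbers rise from methoxy through hydrogen to cyano, each gap beyond the scatter. Nothing at hand accounts for the size of these steps.

Open, going by these compounds, is how an ethoxy, a fluorine or an amine at this place would rank against these three groups.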